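Removing the Acetyl Group from a Purine Amide

The compounds below may be only part of what the source reports. "The series", "measured", "known", "first", "only" and "open" are said of these compounds alone.

Three compounds share a fused two-ring core. Compound 1 `Nc1cc(Cl)c2nc[nH]c2n1` carries a free amino group and in a functional assay on KB cells (Homo sapiens) for cytotoxicity (a lower number here means that less compound is needed, a higher number that more compound is needed for the effect), compound 1 gives 1 ug/mL. Compound 2 `CC(=O)Nc1cc(Cl)c2nc[nH]c2n1` is its acetamide; for compound 2 this assay reports only a limit, > 22 ug/mL. Compound 3 `CSc1cc(NC(C)=O)nc2[nH]cnc12` keeps the acetamide but differs in the core; for compound 3 this assay likewise reports only a limit, > 22 ug/mL. The change hydrogen in place of acetyl on a nitrogen on an aromatic ring produced an at least 22-fold lower number from compound 2 to compound 1 (1.34 log units; beyond the scatter), two of the three values sitting at the limit of > 22 ug/mL in this assay, at which 2 of the 3 values shown sit. The cores of compound 2 and compound 3 differ by methylsulfanyl in place of chloro on an aromatic carbon, which gave a step that the two limits leave unreadable from compound 2 to compound 3. Compound 4 `CSc1cc(N)nc2[nH]cnc12` is still unmeasured; it differs from compound 3 by hydrogen in place of acetyl on a nitrogen on an aromatic ring, the same change as from compound 2 to compound 1, at a place described in identical words. The step from compound 3 to compound 4 is therefore expected to be an at least 7.3-fold lower number from compound 3 to compound 4 (0.86 log units; beyond the scatter), resting on the large step seen from compound 2 to compound 1, though the limit for compound 3 leaves its starting point open. Compound 4 is estimated at 3 ug/mL, between 0.7 ug/mL and 22 ug/mL.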

Compound 4, concentration for half-maximal effect: > 22 ug/mL
Compound 4: a limit, no number; the forecaster's own chance of this, stated with the estimate: 20%; at least 7.3-fold (0.86 log units) between middle value and limit.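

In this assay compound 4 gives > 22 ug/mL, which is a limit and not a number. With the free amino group kept, methylsulfanyl in place of chloro on an aromatic carbon gives an at least 22-fold higher number from compound 1 to compound 4 (1.34 log units; beyond the scatter), so the free amino group does not by itself carry the low number of compound 1 over to the other core. The large step seen on removing the acetyl group from compound 2 is neither confirmed nor ruled out on the methylsulfanyl core, since the steps between compound 3 and compound 4 and between compound 2 and compound 3 cannot be read: the limit of > 22 ug/mL in this assay, at which 3 of the 4 values shown sit.

The compounds shown leave open what number compound 3 and compound 4 would have, and so whether removing the acetyl group changes anything on this core. They also leave open whether a methoxy group, a dimethylamino group or a longer alkylsulfanyl chain on that aromatic carbon would give a value closer to that of compound 1.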